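Swapping a carbamoylamino arm for 4-chlorophenyl

The source may hold more compounds than are shown below. What is called first, only, known or untested is meant among the compounds shown, and "the series" means these compounds.

Measured in a functional assay on MOLT-4 cells (Homo sapiens) for inhibition, read by MTT assay, with a stated time of 72 h; on this read-out higher numbers stand for weaker inhibition and lower numbers for stronger inhibition:
Compound 1 `COc1cc(NC(C)CCCNC(=O)Nc2cccc(Cl)c2)c2ncccc2c1`: 21000 nM
Compound 2 `COc1cc(NC(C)CCCNC(=O)NNC(=O)Nc2ccc(F)cc2)c2ncccc2c1`: >= 250000 nM (a limit, not a number)
Compound 3 `COc1cc(NC(C)CCCNC(=O)NNC(=O)Nc2ccc(Br)cc2)c2ncccc2c1`: 209000 nM

Compound 2 stands at the limit of >= 250000 nM in this assay, at which 1 of the 3 values shown sits, which is a limit and not a number. Compound 4 `COc1cc(NC(C)CCCNC(=O)Nc2ccc(Cl)cc2)c2ncccc2c1` differs from compound 2 at one place: 4-chlorophenyl in place of ((4-fluorophenyl)carbamoyl)amino on an amide-type nitrogen. In words, 4-chlorophenyl takes the place of ((4-fluorophenyl)carbamoyl)amino on an amide-type nitrogen.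

The best guide is the same kind of swap in the opposite direction. The measured steps are an at least 11-fold higher number from compound 1 to compound 2 (1.07 log units; beyond the scatter) and a 10-fold higher number from compound 1 to compound 3 (1.00 log units; beyond the scatter), each with a carbamoylamino group entering in place of 3-chlorophenyl. Replacing fluoro with bromo gave an at least 1.1-fold lower number from compound 2 to compound 3 (0.07 log units; that floor lies within the scatter), so that pair adds little. Compound 4 regains a plain chlorophenyl group, as in compound 1 at 21000 nM, so a value near that one is expected. Among the measured compounds shown here, no measured pair compares 4-chlorophenyl with 3-chlorophenyl, so the range stays wide.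

The expected step is an at least 12-fold lower number from compound 2 to compound 4 (1.09 log units; beyond the scatter) in this assay, a move towards stronger inhibition beyond the scatter. For compound 4 the estimated value is 20000 nM, with an expected range of 7000 nM to 60000 nM.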

Compound 4, half-maximal inhibitory concentration: 24000 nM
Compound 4: the middle estimate sits 1.2-fold (0.08 log units) below what was measured; measured number inside the range.
By their numbers in this assay, from the lowest: compounds 1 and 4 (each within the scatter of the next); then compound 3. At a limit, above all of these: compound 2.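

In this assay the move from 3-chlorophenyl to 4-chlorophenyl gives a 1.1-fold higher number from compound 1 to compound 4 (0.06 log units; within the scatter) and so the two chlorophenyl groups cannot be told apart on this amide-type nitrogen. Removing the carbamoylamino arm now also shows the same large difference in the reverse direction, with an 8.7-fold lower number from compound 3 to compound 4 (0.94 log units; beyond the scatter) as a step between two measured numbers on rings substituted alike at the 4-position. The step of an at least 10-fold lower number from compound 2 to compound 4 (1.01 log units; beyond the scatter) is only a floor, because the starting compound sits at a limit and not at a number: the limit of >= 250000 nM in this assay, at which 1 of the 4 values shown sits.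

Whether the chlorine matters at all remains open, since every aromatic ring shown here carries a halogen and a plain phenyl group is absent. Also open, going by these compounds, is how a saturated ring such as cyclohexyl would behave on this nitrogen.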